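Cytotoxicity notes on the series, toward compound 4

A few compounds are considered here, and "the series" means these few. Any claim that something is new, unique, unknown or untested is made for them only; others in the source may bear on it.

Compound 3 `Cc1cccc(C(=O)c2ccn(-c3ccc4c(c3)B(O)OC4)c2)c1` sits at the assay ceiling in an ADME assay on L929 cells (Mus musculus) for cytotoxicity, read by resazurin assay, with a stated time of 72 h; a higher number here means a weaker inhibitor, a lower number a stronger inhibitor; compound 3 gives > 10 ug/mL, which is a limit of the assay and not a number. Compound 1 `O=C(c1ccc(Cl)cc1)c1ccn(-c2ccc3c(c2)B(O)OC3)c1` gives > 10 ug/mL, likewise a limit. Compound 2 `O=C(c1cccc(Cl)c1)c1ccn(-c2ccc3c(c2)B(O)OC3)c1` gives > 10 ug/mL, also a limit. All three measured values sit at this limit (the limit of > 10 ug/mL in this assay, at which 3 of the 3 values shown sit). The steps among them, a step that the two limits leave unreadable from compound 1 to compound 2, a step that the two limits leave unreadable from compound 1 to compound 3 and a step that the two limits leave unreadable from compound 2 to compound 3, are consequently of unreadable size.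

Compound 4 `CCc1ccc(C(=O)c2ccn(-c3ccc4c(c3)B(O)OC4)c2)cc1` differs from compound 3 by 4-ethylphenyl in place of 3-methylphenyl on a carbonyl carbon. The measured steps that bear on this change, each exchanging one substituent of the phenyl on the carbonyl carbon, give no readable size, so no step beyond the scatter can be drawn from them; every member so far remains at the limit. The expectation for compound 4 in this assay is that it too stays at the limit, with an estimated step that the limit leaves unreadable from compound 3 to compound 4. The estimate for compound 4 is 25 ug/mL, within 10 ug/mL to 60 ug/mL.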

Compound 4, half-maximal inhibitory concentration: > 10 ug/mL
Compound 4 ended at the assay's limit (the forecaster's own chance of this, stated with the estimate: 85%); the middle value is on the limit's open side.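

No step linking compound 4 with compound 1, compound 2 or compound 3 can be read in this assay, because all four compounds stand at the same limit: the limit of > 10 ug/mL in this assay, at which 4 of the 4 values shown sit.

The compounds shown leave open where each true value lies, and whether any substituent on the phenyl at the carbonyl carbon changes cytotoxicity.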